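The source may hold more compounds than are shown below. What is called first, only, known or untested is meant among the compounds shown, and "the series" means these compounds.

Measured compounds:
compound 1, `CCCCCCNc1nc(-c2ccccc2)nc2c1nnn2Cc1ccccc1Cl`, 31000000 nM
compound 2, `c1ccc(Cn2nnc3c(NC4CC4)nc(-c4ccccc4)nc32)cc1`, 11000000 nM
compound 3, `Fc1ccccc1Cn1nnc2c(NC3CC3)nc(-c3ccccc3)nc21`, 15000000 nM

In an assay on isolated protein for binding affinity to adenosine receptor A1 (Bos taurus) (a higher number here means a weaker inhibitor, a lower number a stronger inhibitor), all three compounds sit at the weak end of the scale. Compound 3 has the second highest of the three numbers. Going by the values given here, its nearest neighbour is compound 2, and the single step of a 1.4-fold higher number from compound 2 to compound 3 (0.13 log units; within the scatter) lies within the scatter, so the two compounds cannot be told apart. Among the compounds with values here, the furthest is compound 1, whose number in this assay is 31000000 nM, higher than that of compound 3 by a margin beyond the scatter; compound 1 differs from compound 3 in more than one place, so no single step is recorded between them.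

Compound 4, `Clc1ccccc1Cn1nnc2c(NC3CC3)nc(-c3ccccc3)nc21`, differs from compound 3 by chloro in place of fluoro on an aromatic carbon. Within the data shown here, the only measured step that touches the same position is the one from hydrogen to fluoro, and it stayed within the scatter. Among the measured compounds shown here, compound 1 also carries the chloro group, but with a different amine, so its value shows only that a chloro-bearing compound of this core remains weak. For the measured compounds named here, no measured step shows chloro in place of fluoro directly. On this basis the change is expected to give no step beyond the scatter, a 1.2-fold higher number from compound 3 to compound 4 (0.08 log units; within the scatter). Compound 4 is therefore estimated at 18000000 nM, with a range from 6000000 nM to 50000000 nM.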

Compound 4, inhibition constant: 11000000 nM
Beside the measured number, compound 4's estimate is 1.6-fold (0.21 log units) above it; the measured number falls inside the stated range.
By their numbers in this assay, from the lowest: compounds 2, 4 and 3 (each within the scatter of the next); then compound 1.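

In this assay, the exchange at this aromatic carbon gives a 1.4-fold lower number from compound 3 to compound 4 (0.13 log units; within the scatter) and, with hydrogen as the starting point, no change at the digits printed from compound 2 to compound 4 (within the scatter); together with a 1.4-fold higher number from compound 2 to compound 3 (0.13 log units; within the scatter) as the earlier step, this means that hydrogen, fluoro and chloro at this position cannot be told apart in these compounds. Going by these compounds alone, compound 4 also ties compound 1 to the others through a single change for the first time, and a 2.8-fold lower number from compound 1 to compound 4 (0.45 log units; beyond the scatter) places the only step beyond the scatter at the group on the nitrogen on an aromatic ring, not at the position carrying the halogen. Nothing available here offers an explanation for either result.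

The compounds shown leave open whether a different kind of group at this position, such as methoxy, a nitrile or a carboxylic acid, would give a step beyond the scatter. They also leave open how the number would respond on that nitrogen to other groups, such as a shorter chain or a hydroxyethyl group, and whether the modest step from hexyl to cyclopropyl would hold with fluoro or hydrogen on the benzyl group.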